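This account rests on a few compounds, and the source may have more. Where it says the series, first, only, none or still open, it means among the compounds named here.

Three compounds share one core, a sugar joined to a bicyclic aromatic system that carries a sulfur-linked side chain, and differ in that side chain. In an assay on isolated protein for binding affinity to Equilibrative nucleoside transporter 1 (Homo sapiens) (a lower number here means a stronger inhibitor, a higher number a weaker inhibitor), compound 1 `Cc1cccc(CSc2ncnc3c2ncn3[C@@H]2O[C@H](CO)[C@@H](O)[C@H]2O)c1` gives 12000 nM. Compound 2 `OC[C@H]1O[C@@H](n2cnc3c(CSc4ccc(Br)cc4)ncnc32)[C@H](O)[C@@H]1O` gives 178 nM in this assay, and the step from one to the other is a 67-fold lower number from compound 1 to compound 2 (1.83 log units; beyond the scatter). Compound 3 `COC(=O)c1ccc(SCc2ncnc3c2ncn3[C@@H]2O[C@H](CO)[C@@H](O)[C@H]2O)cc1` gives 813 nM in this assay, which is a 4.6-fold higher number from compound 2 to compound 3 (0.66 log units; beyond the scatter). Compound 3 therefore stands second highest of the three numbers, well below compound 1 and above compound 2.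

Compound 4 `OC[C@H]1O[C@@H](n2cnc3c(CSc4ccc(I)cc4)ncnc32)[C@H](O)[C@@H]1O` has not yet been measured. It differs from compound 3 by iodo in place of methoxycarbonyl on an aromatic carbon. The step that bears on this change most directly is a 4.6-fold higher number from compound 2 to compound 3 (0.66 log units; beyond the scatter). Compound 2 carries a halogen at the same place and compound 3 the methoxycarbonyl; compound 4 puts a different halogen there. The step of a 67-fold lower number from compound 1 to compound 2 (1.83 log units; beyond the scatter) concerns a different part of the side chain and bears only loosely. Reversing the change from compound 2 to compound 3 suggests a number for compound 4 near that of compound 2, so a modest fall is expected, roughly a 5.1-fold lower number from compound 3 to compound 4 (0.71 log units; beyond the scatter). Compound 4 is estimated to give 160 nM in this assay, most likely between 55 nM and 450 nM.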

Compound 4, half-maximal inhibitory concentration: 69.2 nM
The estimate for compound 4 lay 2.3-fold (0.36 log units) above the measured number; the measured number falls inside the stated range.
By their numbers in this assay, from the lowest: compound 4; then compound 2; then compound 3; then compound 1.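

At this ring carbon, para to a large group, this assay responds strongly when the methoxycarbonyl, with its 4 heavy atoms, gives way to the single iodine atom (a 12-fold lower number from compound 3 to compound 4 (1.07 log units; beyond the scatter)), and this comparison adds a second halogen to the picture. The two halogens are not interchangeable here, since iodo in place of bromo gives a change beyond the scatter (a 2.6-fold lower number from compound 2 to compound 4 (0.41 log units; beyond the scatter)), which makes compound 4 the strongest inhibitor of the four and shows that the choice of halogen matters, not merely the presence of one. Set against the side chain of compound 1, the iodinated side chain gives the widest gap in the set (a 170-fold lower number from compound 1 to compound 4 (2.24 log units; beyond the scatter)), although no measurement here explains any of these differences.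

From the compounds shown here alone, only bromo, iodo and methoxycarbonyl are compared at this ring carbon, so it remains open how chloro, fluoro, an amine or a carboxylic acid would behave there. It is also unknown whether iodo would keep its advantage at another carbon of the same ring or with a longer chain joining that ring to the sulfur.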